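This account rests on a few compounds, and the source may have more. Where it says the series, first, only, none or still open, it means among the compounds named here.

Measured in a functional assay on K562 cells (Homo sapiens) for cytotoxicity, read by trypan blue exclusion, with a stated time of 96 h; a higher number here means a weaker inhibitor, a lower number a stronger inhibitor:
compound 1 `COc1ccc(/C=C/S(=O)(=O)Nc2ccc(OC)c(F)c2)cc1` — 1000 nM
compound 2 `O=S(=O)(/C=C/c1ccccc1)Nc1ccc(Cl)cc1` — 20000 nM
compound 3 `COC(=O)CNc1cc(NS(=O)(=O)/C=C/c2c(OC)cc(OC)cc2OC)ccc1OC` — 350 nM

Compound 3 gives the lowest number of the three in this assay; compound 1 stands nearest to it, and the gap between them is beyond the scatter, while compound 2 stands furthest away, also well beyond the scatter.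

Compound 4 `COc1cc(OC)c(/C=C/S(=O)(=O)Nc2ccc(OC)c(NC(C)(C)C(=O)O)c2)c(OC)c1` is not yet measured. It differs from compound 3 in one place: 1-carboxy-1-methylethyl in place of (methoxycarbonyl)methyl on a nitrogen on an aromatic ring. Among the compounds with values here, no measured pair shows this change, so its size is not known from the series; a modest weakening is expected, beyond the scatter but well short of the gap to compound 2. For compound 4 the expected step is a 2.3-fold higher number from compound 3 to compound 4 (0.36 log units; beyond the scatter). Compound 4 is thus estimated at 800 nM, within 250 nM to 2500 nM.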

Compound 4, half-maximal inhibitory concentration: 5 nM
Compound 4: the middle estimate sits 160-fold (2.20 log units) above what was measured, outside the stated range (below it).
By their numbers in this assay, from the lowest: compound 4; then compound 3; then compound 1; then compound 2.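

In this assay, within the data shown here, the change from (methoxycarbonyl)methyl to 1-carboxy-1-methylethyl on this nitrogen gives a 70-fold lower number from compound 3 to compound 4 (1.85 log units; beyond the scatter) and so shows what the earlier compounds could not: this position responds strongly to the group it carries. The size of the step also shows that the shared core does not set the number alone.

The compounds shown do not separate the carboxylic acid from the branched carbon, since both arrive in the one change; a carboxymethyl group or the methyl ester of the branched acid on this nitrogen would divide them. No measurement at hand bears on the cause of the step.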